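Octyl and decyl triazole chalcones with aryl piperazine amides

The compounds below may be only part of what the source reports. "The series", "measured", "known", "first", "only" and "open" are said of these compounds alone.

Three measured compounds share a triazolyl enone amide scaffold. Compound 1 `CCCCCCCCn1cc(/C=C/C(=O)c2ccc(NC(=O)CN3CCN(c4ccccc4F)CC3)cc2)nn1` and compound 2 `CCCCCCCCn1cc(/C=C/C(=O)c2ccc(NC(=O)CN3CCN(c4ccc([N+](=O)[O-])cc4)CC3)cc2)nn1` differ only at the aryl piperazine; compound 3 `CCCCCCCCCCn1cc(/C=C/C(=O)c2ccc(NC(=O)CN3CCN(c4ccc([N+](=O)[O-])cc4)CC3)cc2)nn1` carries the longer chain of compound 2's nitrophenyl series. In a functional assay on HeLa cells (Homo sapiens) for inhibition, read by MTT assay (on this read-out higher numbers stand for weaker inhibition and lower numbers for stronger inhibition), compound 1 gives 33800 nM, compound 2 gives 30200 nM and compound 3 gives 65900 nM.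

The aryl swap 2-fluorophenyl in place of 4-nitrophenyl on an amine nitrogen in a ring gives a 1.1-fold higher number from compound 2 to compound 1 (0.05 log units; within the scatter), so these two values cannot be told apart. The chain extension ethyl in place of hydrogen on a saturated chain carbon, eight bonds along the chain from an aromatic nitrogen gives a 2.2-fold higher number from compound 2 to compound 3 (0.34 log units; beyond the scatter), a modest step in the direction of weaker inhibition.

Compound 4 `CCCCCCCCCCn1cc(/C=C/C(=O)c2ccc(NC(=O)CN3CCN(c4ccccc4F)CC3)cc2)nn1` is not yet measured. It differs from compound 3 by 2-fluorophenyl in place of 4-nitrophenyl on an amine nitrogen in a ring, the same change as that from compound 2 to compound 1, with the two cores differing by ethyl in place of hydrogen on a saturated chain carbon, eight bonds along the chain from an aromatic nitrogen. Because the earlier instance of this swap gave a 1.1-fold higher number from compound 2 to compound 1 (0.05 log units; within the scatter), the step from compound 3 to compound 4 is expected to be about a 1.1-fold higher number from compound 3 to compound 4 (0.03 log units; within the scatter), within the scatter. Compound 4 is therefore estimated at 70000 nM, expected to lie between 35000 nM and 140000 nM.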

Compound 4, half-maximal inhibitory concentration: 47800 nM
Compound 4: the middle estimate sits 1.5-fold (0.17 log units) above what was measured, within the range that was stated.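

In this assay, the swap to 2-fluorophenyl on the decyl core gives a 1.4-fold lower number from compound 3 to compound 4 (0.14 log units; within the scatter), and the two readings of this swap do not differ: the same change on two cores in this assay, a 1.1-fold higher number (0.05 log units; within the scatter) from compound 2 to compound 1 and a 1.4-fold lower number (0.14 log units; within the scatter) from compound 3 to compound 4, 1.5-fold (0.19 log units) apart, within the scatter of two such steps. The chain extension on the 2-fluorophenyl core gives a 1.4-fold higher number from compound 1 to compound 4 (0.15 log units; within the scatter), and its two readings do not differ either: the same change on two cores in this assay, a 2.2-fold higher number (0.34 log units; beyond the scatter) from compound 2 to compound 3 and a 1.4-fold higher number (0.15 log units; within the scatter) from compound 1 to compound 4, 1.5-fold (0.19 log units) apart, within the scatter of two such steps. Each change therefore carries from one core to the other within the limits of these data, but the two aryl steps both lie within the scatter, so there is no clear aryl effect to transfer, and two cores cannot show that either change would behave alike on any other core.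

Going by these compounds, whether a dodecyl chain or a shorter hexyl chain would continue the step seen with the decyl chain remains open. So does whether a plain phenyl or a pyridine ring on the same amine nitrogen would separate from the two aryl groups shown here.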